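The source may hold more compounds than are shown below. What is called first, only, known or untested is meant among the compounds shown, and "the series" means these compounds.

Measured in a functional assay on GOTO cells (Homo sapiens) for cytotoxicity, read by MTT assay, with a stated time of 3 days; on this read-out higher numbers stand for weaker inhibition and lower numbers for stronger inhibition:
Compound 1 `N#Cc1c(NN)nc(SCc2nc3ccccc3[nH]2)nc1-c1ccccc1`: 2.68 nM
Compound 2 `N#Cc1c(NNC(N)=S)nc(SCc2nc3ccccc3[nH]2)nc1-c1ccccc1`: 2.55 nM
Compound 3 `CN1CCN(c2nc(SCc3nc4ccccc4[nH]3)nc(-c3ccccc3)c2C#N)CC1`: 3.37 nM

Compound 3, at 3.37 nM, sits within the usual scatter of both other compounds, so the three cannot be ranked on these numbers. Compound 4 `Cc1ccc(S(=O)(=O)N2CCN(c3nc(SCc4nc5ccccc5[nH]4)nc(-c4ccccc4)c3C#N)CC2)cc1` has (4-methylphenyl)sulfonyl in place of methyl on an amine nitrogen in a ring.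

Within the data shown here, no measured step changes a group on that ring nitrogen, so the evidence is only indirect. The closest guide is the group on the aromatic carbon, where compound 3 differs from the others: a 1.3-fold higher number from compound 1 to compound 3 (0.10 log units; within the scatter) and a 1.3-fold higher number from compound 2 to compound 3 (0.12 log units; within the scatter). A change on the amine nitrogen of compound 1 was also small: a 1.1-fold lower number from compound 1 to compound 2 (0.02 log units; within the scatter). These steps give no direction, so no change beyond the scatter is expected in this assay. The expected step is a 1.2-fold higher number from compound 3 to compound 4 (0.07 log units; within the scatter). Going by these compounds, for compound 4 the estimated value is 4 nM, with an expected range from 1.5 nM to 15 nM, kept wide because the new group is untested.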

Compound 4, half-maximal inhibitory concentration: 4.38 nM
Estimate against measurement, compound 4: 1.1-fold (0.04 log units) below; the measured number falls inside the stated range.
By their numbers in this assay, from the lowest: compounds 2, 1, 3 and 4 (each within the scatter of the next).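

Replacing methyl with (4-methylphenyl)sulfonyl on the ring nitrogen in this assay gives a 1.3-fold higher number from compound 3 to compound 4 (0.11 log units; within the scatter) and stays within the scatter. This is the first change shown at this nitrogen, and it is a large one: a single carbon gives way to 10 heavy atoms, including a six-membered aromatic ring and 2 hydrogen-bond acceptors. Even so, the read-out cannot separate the two compounds, and no measurement here gives a reason for this result.

The compounds shown leave open whether a group of a different kind on this nitrogen, such as a carboxylic acid or a longer chain ending in an amine, would move the number beyond the scatter. They also do not show what a plain hydrogen there would give.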